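Trimming the Benzyl Amide Down to a Carbamoylmethyl Chain

The compounds below may be only part of what the source reports. "The series", "measured", "known", "first", "only" and "open" are said of these compounds alone.

Compound 1, `NC(=O)c1ccc(Cn2ncc3c(Nc4ccc(OC(F)(F)F)cc4)ncnc32)cc1`: in an ADME assay on BaF3 cells (Mus musculus) for cytotoxicity (a higher number here means that more compound is needed for the effect, a lower number that less compound is needed), compound 1 gives > 10000 nM.
Compound 2, `CCn1cc2c(Nc3ccc(OC(F)(F)F)cc3)ncnc2n1`: in this assay compound 2 gives > 10000 nM.

The value of compound 1 is a limit of this assay, not a number. The value of compound 2 is likewise a limit. Compound 1 therefore stands at the ceiling of what this assay reports, where (the limit of > 10000 nM in this assay, at which 2 of the 2 values shown sit).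

Compound 3, `NC(=O)Cn1ncc2c(Nc3ccc(OC(F)(F)F)cc3)ncnc21`, differs from compound 1 by carbamoyl in place of 4-carbamoylphenyl on a saturated chain carbon bound to an aromatic nitrogen. Within the data shown here, no measured step exists for this pair, and in this assay no step beyond the scatter is expected. Compound 3 is estimated at 15000 nM, ranging from 5000 nM to 50000 nM. The expected step is a step that the limit leaves unreadable from compound 1 to compound 3.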

Compound 3, half-maximal effective concentration: 3300 nM
Compound 3: middle estimate off by 4.5-fold (0.66 log units), on the high side; the whole stated range lies above it.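

Carbamoylmethyl at this position gives a read-out inside the measurable range of this assay, so less compound is needed for the cytotoxic effect after the change from 4-carbamoylbenzyl: an at least 3.0-fold lower number from compound 1 to compound 3 (0.48 log units; beyond the scatter). That step is only a minimum, because the starting point sits at a limit of the assay: the limit of > 10000 nM in this assay, at which 2 of the 3 values shown sit.

The compounds shown do not separate the loss of the phenyl ring from the shortening of the chain. A longer chain ending in the same amide, or a carboxylic acid in place of the amide, would bear on what drives the change.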